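The compounds below may be only part of what the source reports. "The series", "measured", "known", "first", "only" and "open" are said of these compounds alone.

Compound 3 `CCCS(=O)(=O)N1CC=C(c2ccc3c(c2)CC(C2CCN(c4ncc(C(F)(F)F)cn4)CC2)O3)CC1` gives the lowest number of the three measured compounds in a functional assay on HEK293 cells for agonist activity at Glucose-dependent insulinotropic receptor (Homo sapiens), read by cAMP accumulation, with a stated time of 60 min (a lower number here means that less compound is needed, a higher number that more compound is needed for the effect), namely 14 nM. Compound 1 `CCCS(=O)(=O)N1CC=C(c2ccc3c(c2)CC(C2CCN(C(=O)OC4CCCCC4)CC2)O3)CC1` gives 51 nM and compound 2 `CCCS(=O)(=O)N1CC=C(c2ccc3c(c2)CC(C2CCN(c4ncc(Cl)cn4)CC2)O3)CC1` gives 78 nM; the steps of a 3.6-fold lower number from compound 1 to compound 3 (0.56 log units; beyond the scatter) and a 5.6-fold lower number from compound 2 to compound 3 (0.75 log units; beyond the scatter) both lie beyond the scatter. Compound 4 `CCCc1cnc(N2CCC(C3Cc4cc(C5=CCN(S(=O)(=O)CCC)CC5)ccc4O3)CC2)nc1` differs from compound 3 by propyl in place of trifluoromethyl on an aromatic carbon. Among the measured compounds shown here, the only measured step at this position is a 5.6-fold lower number from compound 2 to compound 3 (0.75 log units; beyond the scatter), in which one small group replaced another; no measured step involves propyl, so this change is not anchored by the data. Compound 4 is expected to show a 1.8-fold higher number from compound 3 to compound 4 (0.25 log units; within the scatter), a change likely within the scatter. The estimate for compound 4 is 25 nM, with a range from 8 nM to 80 nM.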

Compound 4, half-maximal effective concentration: 82 nM
Compound 4: the middle estimate sits 3.3-fold (0.52 log units) below what was measured, and the stated range ends below it.
By their numbers in this assay, from the lowest: compound 3; then compounds 1, 2 and 4 (each within the scatter of the next).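

At this aromatic carbon in this assay the low number does not survive the change from trifluoromethyl to propyl (a 5.9-fold higher number from compound 3 to compound 4 (0.77 log units; beyond the scatter)). Propyl instead sits level with chloro (a 1.1-fold higher number from compound 2 to compound 4 (0.02 log units; within the scatter)), and the 5-propylpyrimidin-2-yl compound sits level with the cyclohexyloxycarbonyl one (a 1.6-fold higher number from compound 1 to compound 4 (0.21 log units; within the scatter)), so among the groups shown on this carbon only trifluoromethyl stands apart. No measurement here explains why this one group differs. As far as these compounds go, whether a nitrile, a methyl group or a longer chain on this carbon would match trifluoromethyl remains open.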